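The compounds below may be only part of what the source reports. "The series", "measured", "known", "first", "only" and "open" are said of these compounds alone.

Measured compounds in a functional assay on P388 cells (Mus musculus) for cytotoxicity; on this read-out lower numbers stand for an effect already at smaller amounts and higher numbers for an effect only at larger amounts of compound:
compound 1 `Oc1cc(-c2ccccc2)nc2c(O)cccc12` gives > 10 ug/mL
compound 2 `CS(=O)(=O)Oc1cc(-c2ccccc2)nc2ccccc12` gives > 10 ug/mL

Both measured values are limits of this assay rather than numbers. Compound 1 shows > 10 ug/mL, which is a limit. Compound 2 shows > 10 ug/mL, again a limit and not a number. Among the measured compounds shown here, compound 2 therefore sits at the limit of > 10 ug/mL in this assay, at which 2 of the 2 values shown sit, where compound 1 also sits, so no step between measured compounds can be read from these two values. The unmeasured compound 3 `CCCOc1cc(-c2ccccc2)nc2ccccc12` differs from compound 2 in a single place: propyl in place of methylsulfonyl on an oxygen on an aromatic ring. For the measured compounds named here, with no measured step to lean on, the step expected from compound 2 to compound 3 is a step that the limit leaves unreadable from compound 2 to compound 3, that is, none beyond the usual scatter. Compound 3 is accordingly estimated to give 15 ug/mL, with a range from 3 ug/mL to 60 ug/mL, most probably reported once more only as a limit.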

Compound 3, half-maximal effective concentration: 6.9 ug/mL
Compound 3: the middle estimate sits 2.2-fold (0.34 log units) above what was measured; the measured number falls inside the stated range.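

In this assay compound 3 gives 6.9 ug/mL, the first number rather than a limit among the compounds shown, so this oxygen on an aromatic ring now has a substituent with a readable value. Compound 2 gives > 10 ug/mL, which is a limit. Propyl in place of methylsulfonyl at this place therefore gives an at least 1.4-fold lower number from compound 2 to compound 3 (0.16 log units; that floor lies within the scatter), and only this floor of the step can be read, since the value it starts from is the shared limit: the limit of > 10 ug/mL in this assay, at which 2 of the 3 values shown sit.

From the compounds shown here alone, whether the number of compound 3 is particular to propyl stays open. A longer chain such as butyl, or a chain ending in an amine or a carboxylic acid, on the same oxygen would be needed to show how this place responds to the group it carries.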